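The source may hold more compounds than are shown below. What is called first, only, known or untested is meant among the compounds shown, and "the series" means these compounds.

Compound 1, `Cc1ccc(NC(=O)Nc2cc(C)nc3ccccc23)cc1`: in an ADME assay on HEK293 cells (Homo sapiens) for cytotoxicity, with a stated time of 72 h (on this read-out higher numbers stand for an effect only at larger amounts of compound and lower numbers for an effect already at smaller amounts), compound 1 gives > 25000 nM, which is a limit of the assay and not a number.
Compound 2, `CSc1ccc(NC(=O)Nc2cc(C)nc3ccccc23)cc1`: in this assay compound 2 gives 24000 nM.
Compound 3, `Cc1cc(NC(=O)Nc2ccc(N(C)C)cc2)c2ccccc2n1`: in this assay compound 3 gives > 25000 nM, again a limit of the assay.

Compound 1 therefore stands at the upper edge of what the assay reports, and compound 3 sits at the same edge (the limit of > 25000 nM in this assay, at which 2 of the 3 values shown sit). The three measured steps all change the substituent on the aromatic carbon of the phenyl ring: an at least 1.0-fold lower number from compound 1 to compound 2 (0.01 log units; that floor lies within the scatter), an at least 1.0-fold higher number from compound 2 to compound 3 (0.01 log units; that floor lies within the scatter), and a step that the two limits leave unreadable from compound 1 to compound 3. None of them moves the read-out by more than the scatter, and two of the three end at the limit.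

Compound 4, `Cc1cc(NC(=O)Nc2cccnc2)c2ccccc2n1`, differs from compound 1 in another way: pyridin-3-yl in place of 4-methylphenyl on an amide-type nitrogen. For the measured compounds named here, no measured step exchanges the ring itself, so the evidence bears on this change only indirectly, in that every alteration at that end of the shared core left the read-out at or close to the limit. On that basis no step beyond the scatter is expected, a number no higher from compound 1 to compound 4 (the limit leaves the size open). Compound 4 is estimated to give 25000 nM in this assay, with a range from 12000 nM to 50000 nM, and a limit rather than a number is the likelier outcome.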

Compound 4, half-maximal effective concentration: > 25000 nM
Compound 4 ended at the assay's limit; the forecaster's own chance of this, stated with the estimate: 65%; the middle value sits exactly at the limit.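

In this assay compound 4 gives > 25000 nM, a limit of the assay and not a number. Compound 1 also stands at a limit, so no step from compound 1 to compound 4 can be read: the limit of > 25000 nM in this assay, at which 3 of the 4 values shown sit.

The compounds shown leave open how compound 1, compound 3 and compound 4 truly differ from one another on this read-out.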